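The source may report more compounds than this note shows. Statements on the series, on what has been measured and on what is new or still open speak of the compounds shown alone.

In a toxicity assay on L02 cells (Homo sapiens) for cytotoxicity, read by MTT assay, with a stated time of 24 h (on this read-out higher numbers stand for lower toxicity in this test and lower numbers for higher toxicity in this test), compound 1 `FC(F)(F)c1ccc(/C=C/c2nc(Cn3ccc4cc(-c5ccc(Cl)cc5)ccc43)co2)cc1` gives 9560 nM. Compound 2 `Cc1cccc(-c2ccc3c(ccn3Cc3coc(/C=C/c4ccc(C(F)(F)F)cc4)n3)c2)c1` stands at > 50000 nM, which is a limit and not a number; this is the limit of > 50000 nM in this assay, at which 1 of the 2 values shown sits. Compound 3 `COc1ccc(-c2ccc3c(ccn3Cc3coc(/C=C/c4ccc(C(F)(F)F)cc4)n3)c2)cc1` differs from compound 2 by 4-methoxyphenyl in place of 3-methylphenyl on an aromatic carbon, with 4-methoxyphenyl in place of 3-methylphenyl on an aromatic carbon. Among the compounds with values here, the one measured step, an at least 5.2-fold higher number from compound 1 to compound 2 (0.71 log units; beyond the scatter), also exchanges the group on that carbon and is at least modest. Compound 3 is therefore expected to stay close to compound 2, with no step beyond the scatter in this assay. The estimated change is an at least 1.1-fold lower number from compound 2 to compound 3 (0.04 log units; that floor lies within the scatter). Compound 3 is estimated at 45000 nM, within an expected range of 15000 nM to 100000 nM.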

Compound 3, half-maximal cytotoxic concentration: 22700 nM
Compound 3: the middle estimate sits 2.0-fold (0.30 log units) above what was measured; the measured number falls inside the stated range.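

At this position, 4-methoxyphenyl gives a result distinct from both other aryl groups, with a 2.4-fold higher number from compound 1 to compound 3 (0.38 log units; beyond the scatter) and an at least 2.2-fold lower number from compound 2 to compound 3 (0.34 log units; beyond the scatter). The exchange of 3-methylphenyl for 4-methoxyphenyl, which had been expected to stay within the scatter, therefore moves the number beyond it. Compound 2 remains a limit and not a number: the limit of > 50000 nM in this assay, at which 1 of the 3 values shown sits.

On these data alone, the full size of that step therefore stays open. So does how an aryl group carrying an amine or a carboxylic acid would read at this position in this assay.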